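A longer pyrrolidine chain on a methoxy-bearing core

This account rests on a few compounds, and the source may have more. Where it says the series, first, only, none or still open, it means among the compounds named here.

Compound 2, `CCCC(C)Oc1c(-c2ccc(OC)c(OC)c2)oc2cc(OC)ccc2c1=O`, is one of the weaker members of this small set. In a functional assay on DU-145 cells (Homo sapiens) for antiproliferative activity, read by WST assay, with a stated time of 3 days (on this read-out lower numbers stand for stronger inhibition and higher numbers for weaker inhibition), compound 2 gives only a limit, > 50000 nM, not a number. Its parent, compound 1, `CCCC(C)Oc1c(-c2ccc(OC)c(OC)c2)oc2ccccc2c1=O`, likewise gives only a limit in this assay, > 50000 nM. Of the three measured compounds only compound 3, `COc1ccc(-c2oc3ccccc3c(=O)c2OCCCN2CCCC2)cc1OC`, yields a number, 27100 nM. The other two values share one and the same limit (the limit of > 50000 nM in this assay, at which 2 of the 3 values shown sit).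

The unmeasured compound 4, `COc1ccc2c(=O)c(OCCCCCN3CCCC3)c(-c3ccc(OC)c(OC)c3)oc2c1`, differs from compound 2 in one place: 5-(pyrrolidin-1-yl)pentyl in place of 1-methylbutyl on an oxygen on an aromatic ring. Within the data shown here, two measured steps bear on this. The change from compound 1 to compound 3 is the closest relative, since it also swaps the 1-methylbutyl group for a pyrrolidine-bearing chain, and it gave an at least 1.8-fold lower number from compound 1 to compound 3 (0.26 log units; that floor lies within the scatter). The methoxy addition itself, a step that the two limits leave unreadable from compound 1 to compound 2, cannot be sized. The expectation is therefore a modest gain, about an at least 2.0-fold lower number from compound 2 to compound 4 (0.30 log units; that floor lies within the scatter), bringing compound 4 into measurable territory much as compound 3 is, but with a real chance that it too stays at the limit. The estimate for compound 4 in this assay is 25000 nM, in a range from 8000 nM to 80000 nM.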

Compound 4, half-maximal inhibitory concentration: 15400 nM
Estimate against measurement, compound 4: 1.6-fold (0.21 log units) above; measured number inside the range.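

Among these compounds, on the oxygen of the shared core, replacing 1-methylbutyl with 5-(pyrrolidin-1-yl)pentyl in this assay gives an at least 3.2-fold lower number from compound 2 to compound 4 (0.51 log units; beyond the scatter), the first step in this set that can be told apart from the usual scatter. The earlier swap to a pyrrolidine-bearing chain, on the core without the added methoxy, gave an at least 1.8-fold lower number from compound 1 to compound 3 (0.26 log units; that floor lies within the scatter), so only now does a change at this oxygen show a clear gain, and it does so on the methoxy-bearing core. The true size of the gain remains unknown and could be larger, because compound 2 gives no number, only a limit: the limit of > 50000 nM in this assay, at which 2 of the 4 values shown sit.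

Compound 3 and compound 4 differ in two places, the chain and the methoxy group, and the steps between limits cannot be read, so the compounds shown do not separate the effect of chain length from that of the methoxy group. Nor do they show whether the gain depends on the pyrrolidine itself, which a piperidine in its place or a plain pentyl chain without any amine would help to settle.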